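A few compounds are considered here, and "the series" means these few. Any claim that something is new, unique, unknown or untested is made for them only; others in the source may bear on it.

In an ADME assay on microsomes from liver (Rattus norvegicus) for metabolic stability, read by LC-MS, with a stated time of 10 min, tested at 0.5 uM (a higher number here means that more of the compound is left, a lower number that less of the compound is left), compound 2 (`c1cnc2c(c1)CN[C@H](CN(CCCN1CCNCC1)[C@H]1CCCc3cccnc31)C2`) gives 87%, the highest of the three numbers, ahead of compound 1 (`c1ccc2c(c1)CN[C@@H](CN(CC1CCNCC1)[C@H]1CCCc3cccnc31)C2`) at 65% and compound 3 (`c1ccc2c(c1)CN[C@@H](CN(CCCN1CCN(C3CC3)CC1)[C@H]1CCCc3cccnc31)C2`) at 2%. The change to compound 4 (`c1cnc(CN(CCCN2CCNCC2)[C@H]2CCCc3cccnc32)nc1`) is a group of 6 heavy atoms (4 carbon, 2 nitrogen; one six-membered aromatic ring with 2 hetero atoms) in place of a group of 10 heavy atoms (8 carbon, 2 nitrogen; one six-membered non-aromatic ring with 1 hetero atom, one six-membered aromatic ring with 1 hetero atom), on a saturated chain carbon bound to an amine nitrogen, the entering group being pyrimidin-2-yl. Among the compounds with values here, the one measured step, a number 63 percentage points lower from compound 1 to compound 3 (beyond the scatter), is large, but it exchanges a different group, so it shows only that numbers in this assay can move far. Within the data shown here, no measured step covers the present exchange, and the expectation is correspondingly loose. The expected change is a number 5 percentage points lower from compound 2 to compound 4 (within the scatter), not beyond the scatter. For compound 4 the estimated value is 82%, with an expected range of 62% to 96%.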

Compound 4, percent of the compound remaining: 68%
Estimate against measurement, compound 4: 14 percentage points above; the measured number falls inside the stated range.
By their numbers in this assay, from the lowest: compound 3; then compounds 1 and 4 (each within the scatter of the next); then compound 2.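

In this assay, the step at this position, on a saturated chain carbon bound to an amine nitrogen, is a number 19 percentage points lower from compound 2 to compound 4 (beyond the scatter). It shows that this position affects the percent remaining even with the piperazine chain held constant, and that pyrimidin-2-yl, with no hydrogen-bond donor, still leaves compound 4 at 68%. No data on hand account for this step.

The step removes a non-aromatic ring and a hydrogen-bond donor and changes the aromatic ring at once, so their shares remain unresolved. A phenyl or a pyridin-2-yl group at this place would help separate them.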